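Methyl in place of chloro: next step in the series

The compounds below may be only part of what the source reports. "The series", "measured", "known", "first", "only" and "open" are said of these compounds alone.

Among the measured compounds shown here, compound 1 `CC(C)(C)Cc1c(-c2cccc(F)c2F)sc(N)c1C(=O)c1ccc(Cl)cc1` and compound 2 `CC(C)(C)Cc1c(Br)sc(N)c1C(=O)c1ccc(Cl)cc1` are the two measured members. In an assay on CHO cells for displacement of a labelled ligand from adenosine receptor A3 (Homo sapiens), read by scintillation counting, tested at 10 uM (a higher number here means more inhibition at the concentration tested (going by the name of the read-out), a lower number less inhibition), compound 1 gives 1%, and compound 2 gives 1%. The step of no change at the digits printed from compound 1 to compound 2 (within the scatter) shows that bromo in place of 2,3-difluorophenyl on an aromatic carbon left the read-out where it was, at the floor of the scale. Compound 2 therefore stands level with compound 1 at the digits shown; neither shows inhibition worth the name at the concentration tested.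

Compound 3 `Cc1ccc(C(=O)c2c(N)sc(Br)c2CC(C)(C)C)cc1` is the next member. Its difference from compound 2 is methyl in place of chloro on an aromatic carbon. For the measured compounds named here, the only measured step, no change at the digits printed from compound 1 to compound 2 (within the scatter), concerns a different place on the shared core and was flat, so no measured step speaks directly to this change. Both measured compounds sit at the floor, and a swap of one heavy atom for one heavy atom on the six-membered ring gives no ground to expect a rise. The step of a number 2 percentage points higher from compound 2 to compound 3 (within the scatter) is expected to be none beyond the scatter. Compound 3 is estimated at 3%, with a range from -10% to 18%.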

Compound 3, a percentage reported as inhibition, at one concentration (the size of the read-out at that concentration, not a potency): 1%
Compound 3: middle estimate off by 2 percentage points, on the high side; measured number inside the range.
By their numbers in this assay, from the lowest: compounds 1, 2 and 3 (each within the scatter of the next).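

In this assay, going from 4-chlorophenyl to 4-methylphenyl gives no change at the digits printed from compound 2 to compound 3 (within the scatter), so this swap on the six-membered aromatic ring, para to a large group, does not lift the read-out from the level of compound 2 at 1%. Among the compounds shown here, this is the first reading at this position, and it joins the earlier step at a different place on the shared core, no change at the digits printed from compound 1 to compound 2 (within the scatter), so neither of the two places changed so far has moved the number. With the values this low, the result shows only that neither chloro nor methyl at this position gives appreciable inhibition at the concentration tested, and no measurement at hand offers an explanation for this.

As far as these compounds go, whether any group at this position can raise the read-out stays open: an amine, a carboxylic acid or a longer chain here could behave differently, and these compounds give no direction. From the compounds shown here alone, with all the values this low, a loss of inhibition could hardly be seen, so it also remains open whether this position matters at all for displacement of the labelled ligand.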